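This account rests on a few compounds, and the source may have more. Where it says the series, first, only, none or still open, it means among the compounds named here.

Series notes. In a functional assay on A-375 cells (Homo sapiens) for inhibition, read by sulforhodamine B assay, with a stated time of 48 h (on this read-out lower numbers stand for stronger inhibition of growth and higher numbers for weaker inhibition of growth), compound 1 `COC(=O)c1sc2cc(-c3cnn(C)c3)cnc2c1N` reaches only a limit of the assay and gives > 150000 nM. Compound 2 `COC(=O)c1sc2cc(-c3cccnc3)cnc2c1N` likewise gives only a limit in this assay, namely > 112000 nM. Among the measured compounds shown here, the one measured step, a step that the two limits leave unreadable from compound 1 to compound 2, therefore cannot be sized: both ends are limits, one at the limit of > 112000 nM in this assay, at which 1 of the 2 values shown sits, and the other at the limit of > 150000 nM in this assay, at which 1 of the 2 values shown sits. On the numbers shown compound 2 thus stands at a limit, and no value in the set is an actual number.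

Compound 3 `COC(=O)c1sc2cc(-c3ccc(OC)nc3)cnc2c1N` differs from compound 2 by one change: methoxy in place of hydrogen on an aromatic carbon. For the measured compounds named here, no measured step bears on this change directly, and the single measured step in the set is unreadable, so it supplies neither a size nor a direction to carry over. With both measured compounds sitting at limits, the working expectation is that compound 3 also sits at or near the limit. For compound 3 the step is expected to be a step that the limit leaves unreadable from compound 2 to compound 3, none beyond the scatter. Compound 3 is estimated at 150000 nM, with a range from 50000 nM to 300000 nM.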

Compound 3, concentration for 50% growth inhibition: > 37500 nM
Compound 3 gave a limit, no number; the forecaster's own chance of this, stated with the estimate: 80%; the middle value does not contradict the limit.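

Compound 3 gives only a limit, as compound 2 does, so no step can be read between them, and methoxy in place of hydrogen on an aromatic carbon has neither a size nor a direction here. The compounds shown leave open how the groups carried on the shared core compare in this assay, as all three results are limits.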